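The source may hold more compounds than are shown below. What is called first, only, known or untested is meant among the compounds shown, and "the series" means these compounds.

Of the compounds shown here, three that share one core have been tested in a functional assay on DU-145 cells (Homo sapiens) for inhibition, read by sulforhodamine B assay, with a stated time of 48 h; on this read-out higher numbers stand for lower toxicity in this test and lower numbers for higher toxicity in this test. Compound 1 `Nc1cc(N)c2nc(-c3ccccc3)c(Oc3ccc(Cl)c(Cl)c3)nc2c1` carries a 3,4-dichlorophenoxy group on that core. In this assay compound 1 gives < 100000 nM, which is a limit of the test rather than a number. For the measured compounds named here, compound 2 `Nc1cc(N)c2nc(-c3ccccc3)c(NCc3ccc(F)cc3)nc2c1` carries a (4-fluorobenzyl)amino group instead, and in this assay compound 2 gives 9770 nM, the only genuine number among the three. Compound 3 `COc1ccc(CNc2nc3cc(N)cc(N)c3nc2-c2ccccc2)cc1` has methoxy in place of fluoro, and in this assay compound 3 gives < 100000 nM, again a limit. The step from compound 1 to compound 2 is a step that the limit leaves unreadable from compound 1 to compound 2, and the step from compound 2 to compound 3 is a step that the limit leaves unreadable from compound 2 to compound 3, both because of the limit of < 100000 nM in this assay, at which 2 of the 3 values shown sit.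

Compound 4 `COc1ccc(Sc2nc3cc(N)cc(N)c3nc2-c2ccccc2)cc1` differs from compound 2 by (4-methoxyphenyl)sulfanyl in place of (4-fluorobenzyl)amino on an aromatic carbon. Going by the values given here, no measured step gives a readable size for such a change, so the expectation for compound 4 rests on compound 2 alone, with the two limits as a warning. For compound 4 the expected step from compound 2 is a 2.0-fold higher number from compound 2 to compound 4 (0.31 log units; beyond the scatter), and compound 4 is estimated to give 20000 nM in this assay, within a range from 3000 nM to 100000 nM.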

Compound 4, concentration lethal to 50% of the cells: 69200 nM
Compound 4: the middle estimate sits 3.5-fold (0.54 log units) below what was measured; low and high end bracket the measured number.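

In this assay, (4-methoxyphenyl)sulfanyl in place of (4-fluorobenzyl)amino gives a 7.1-fold higher number from compound 2 to compound 4 (0.85 log units; beyond the scatter), which points toward lower toxicity in this test. This gives the position next to the ring nitrogen its first readable step, between two groups that each have 9 heavy atoms and one six-membered aromatic ring of carbon only, though with 0 hydrogen-bond donors in the entering group against 1 in the group that leaves. The other steps among these compounds cannot be read because they involve a value that is a limit of the test: the limit of < 100000 nM in this assay, at which 2 of the 4 values shown sit.

As far as these compounds go, this change swaps the link to the core and the group on the outer ring together, so the share of each in the step stays open. From the compounds shown here alone, how a morpholine ring or a carboxylic acid at this position would read in this assay also stays open.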